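This account rests on a few compounds, and the source may have more. Where it says the series, first, only, none or still open, it means among the compounds named here.

Compound 1 `CC(C)S(=O)(=O)OC1CCC(CN2CCN(c3cc(=O)c4cc(C(F)(F)F)cc([N+](=O)[O-])c4s3)CC2)CC1` stands on the numbers shown only as a limit. In an ADME assay on Vero cells (Chlorocebus sabaeus) for cytotoxicity, read by MTT assay, with a stated time of 48 h (on this read-out higher numbers stand for weaker inhibition and lower numbers for stronger inhibition), compound 1 gives > 64 ug/mL, which is a limit of the assay and not a number. Compound 2 `CS(=O)(=O)NC1CCC(CN2CCN(c3cc(=O)c4cc(C(F)(F)F)cc([N+](=O)[O-])c4s3)CC2)CC1`, with methanesulfonamido on the saturated ring carbon, gives 48.5 ug/mL in this assay. Compound 3 `COc1cccc(C(=O)OC2CCC(CN3CCN(c4cc(=O)c5cc(C(F)(F)F)cc([N+](=O)[O-])c5s4)CC3)CC2)c1` gives > 64 ug/mL in this assay, again a limit of the assay. Two of the three values sit at the same limit, (the limit of > 64 ug/mL in this assay, at which 2 of the 3 values shown sit), so the series is read mostly from one side. The measured steps are an at least 1.3-fold lower number from compound 1 to compound 2 (0.12 log units; that floor lies within the scatter), a step that the two limits leave unreadable from compound 1 to compound 3 and an at least 1.3-fold higher number from compound 2 to compound 3 (0.12 log units; that floor lies within the scatter); none of them is readable beyond the scatter.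

Compound 4 `CC(=O)NC1CCC(CN2CCN(c3cc(=O)c4cc(C(F)(F)F)cc([N+](=O)[O-])c4s3)CC2)CC1` is not yet measured. It differs from compound 1 by acetamido in place of (isopropylsulfonyl)oxy on a saturated ring carbon. Within the data shown here, the step that bears on it is the one to compound 2, where an amido group likewise replaced (isopropylsulfonyl)oxy and the number moved, if at all, only a little toward lower values. For compound 4 a step of similar small size in the same direction is therefore expected, an at least 1.2-fold lower number from compound 1 to compound 4 (0.10 log units; that floor lies within the scatter), with no change beyond the scatter ruled out. Compound 4 is expected to give about 50 ug/mL in this assay, most likely between 25 ug/mL and 100 ug/mL, with a fair chance that only a limit is reported.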

Compound 4, half-maximal inhibitory concentration: > 64 ug/mL
Compound 4 ended at the assay's limit; the forecaster's own chance of this, stated with the estimate: 40%; middle value at least 1.2-fold (0.10 log units) from the limit.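

In this assay, acetamido on the saturated ring carbon leaves the reading at the limit, so a nitrogen-linked group at this place does not by itself bring the number under that limit, and compound 2 remains the only compound with a measured number: the limit of > 64 ug/mL in this assay, at which 3 of the 4 values shown sit.

Among these compounds, the one readable step exchanges acetyl for methylsulfonyl on the same amine nitrogen and gives an at least 1.3-fold higher number from compound 2 to compound 4 (0.12 log units; that floor lies within the scatter), so this pair cannot be told apart on the floor of that step. The steps to compound 4 from compound 1 and from compound 3 join two limits and cannot be read, which means that replacing either oxygen-linked group with acetamido shows no readable effect.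

How far compound 1, compound 3 and compound 4 lie past the limit remains open, and with it any order among these three. Also open, as far as these compounds go, is whether a free amine, a carboxylic acid or a longer chain on this saturated ring carbon would move the number in this assay beyond the scatter, in either direction.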